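The compounds below may be only part of what the source reports. "The series", "measured", "known", "first", "only" and "open" are said of these compounds alone.

compound 1 `COc1ccc(C(O)C2OC(=O)c3c(OC)cc(OC)cc32)cc1`: > 40000 nM
compound 2 `CCCCCCOc1ccc(C(O)C2OC(=O)c3c(OC)cc(OC)cc32)cc1`: > 40000 nM
compound 3 `CCOCCOc1ccc(C(O)C2OC(=O)c3c(OC)cc(OC)cc32)cc1`: > 40000 nM

These three compounds were tested in an ADME assay on RAW264.7 cells (Mus musculus) for cytotoxicity, read by MTT assay, with a stated time of 24 h, in the absence of a further agent; a higher number here means a weaker inhibitor, a lower number a stronger inhibitor. Compound 3 gives > 40000 nM, which is a limit and not a number. It shares that position with the others: the limit of > 40000 nM in this assay, at which 3 of the 3 values shown sit.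

Compound 4 `C=CCCOc1ccc(C(O)C2OC(=O)c3c(OC)cc(OC)cc32)cc1` differs from compound 3 as follows: vinyl in place of ethoxy on a saturated chain carbon, two bonds along the chain from an oxygen on an aromatic ring. In words, vinyl replaces ethoxy on a saturated chain carbon, two bonds along the chain from an oxygen on an aromatic ring.

For the measured compounds named here, three measured steps bear on this change, and none has a readable size: a step that the two limits leave unreadable from compound 1 to compound 2, a step that the two limits leave unreadable from compound 1 to compound 3 and a step that the two limits leave unreadable from compound 2 to compound 3. No chain so far has left the limit, so no clear change is expected in this assay.

The expected step is a step that the limit leaves unreadable from compound 3 to compound 4.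

For compound 4 the estimate is 55000 nM, with an expected range of 30000 nM to 100000 nM.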

Compound 4, half-maximal inhibitory concentration: > 40000 nM
Compound 4: a limit, no number (the forecaster's own chance of this, stated with the estimate: 88%); the middle value is on the limit's open side.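

Compound 4 gives a limit and not a number, as do compound 1, compound 2 and compound 3, so no step among them can be read in this assay: the limit of > 40000 nM in this assay, at which 4 of the 4 values shown sit.

These compounds leave open how far any of them lies beyond that limit, and whether their chains differ at all in this assay.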